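The source may report more compounds than this note shows. Statements on the series, on what has been measured and on what is new or still open speak of the compounds shown alone.

Working notes on the series.

Of the compounds shown here, three of the shared core have been measured in an assay for inhibition of beta-glucuronidase (Bos taurus), read by spectrophotometry, with a stated time of 30 min; a lower number here means a stronger inhibitor, a higher number a weaker inhibitor. Compound 1 `COC(=O)C1=C(C)NC(=O)NC1c1cccc(OC)c1OC` gives 54200 nM. Compound 2 `CCC1NC(=O)NC(C)=C1C(=O)OC` gives 52200 nM. Compound 3 `CCCCC1NC(=O)NC(C)=C1C(=O)OC` gives 78200 nM, the highest of the three numbers, though its gaps to compound 1 and to compound 2 both lie within the scatter, so no order among them can be read from these values.

Going by the values given here, the one step between measured neighbours, from compound 2 to compound 3, is a 1.5-fold higher number from compound 2 to compound 3 (0.18 log units; within the scatter); lengthening the chain did nothing beyond the scatter.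

Compound 4 `COC(=O)C1=C(C)NC(=O)NC1c1ccc(C)o1` differs from compound 3 by 5-methylfuran-2-yl in place of butyl on a saturated ring carbon. Among the compounds with values here, no measured step matches a swap of a chain for a five-membered aromatic ring at this position. The nearest comparison is compound 1, which carries an aromatic ring at the same ring carbon; its value and that of compound 3 lie within the scatter of each other. Within the data shown here, nothing measured so far suggests that what sits on this carbon moves the half-maximal inhibitory concentration beyond the scatter, so compound 4 is expected near the values already seen.

Compound 4 is estimated at 58000 nM, with a range from 25000 nM to 130000 nM. This amounts to an expected step of a 1.3-fold lower number from compound 3 to compound 4 (0.13 log units; within the scatter).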

Compound 4, half-maximal inhibitory concentration: 44200 nM
For compound 4 the middle estimate is 1.3-fold (0.12 log units) above the measured one; the measured number falls inside the stated range.
By their numbers in this assay, from the lowest: compounds 4, 2, 1 and 3 (each within the scatter of the next).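

In this assay, the swap of an open chain for an aromatic ring on the saturated ring carbon can now be read directly, as a 1.8-fold lower number from compound 3 to compound 4 (0.25 log units; within the scatter) with butyl leaving and as a 1.2-fold lower number from compound 2 to compound 4 (0.07 log units; within the scatter) with ethyl leaving. Both steps lie within the scatter, so 5-methylfuran-2-yl, which brings a five-membered aromatic ring and a hydrogen-bond acceptor, gives no readable difference from either chain at this carbon. No independent measurement bears on this result.

Whether anything on this carbon can move the number beyond the scatter remains open, since the groups shown there span only ethyl, butyl and the two aromatic rings of compound 1 and compound 4, and a primary amine, a carboxylic acid or a chain longer than butyl could test this. All four compounds also share the methoxycarbonyl group and the methyl group on the core, so what a carboxylic acid in place of the methoxycarbonyl group or an ethyl in place of the methyl group would do is also unknown.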